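The compounds below may be only part of what the source reports. "The series", "measured", "known", "first", "only" and "open" are said of these compounds alone.

Compound 1 `COc1ccc2c(N)c(C(=O)NCc3ccc(F)cc3F)c(=O)n(O)c2n1`: 2200 nM
Compound 2 `Nc1c(C(=O)NCc2ccc(F)cc2F)c(=O)n(O)c2ncc(CCCCc3ccccc3)cc12`: 13000 nM

In an ADME assay on HOS cells (Homo sapiens) for cytotoxicity, read by luminescence and ATP content, with a stated time of 48 h (a lower number here means that less compound is tolerated, a higher number that more compound is tolerated), compound 2 stands highest of the two at 13000 nM, and the gap down to compound 1 at 2200 nM lies beyond the scatter. Compound 3 `CC(C)NC(=O)/C=C/c1cnc2c(c1)c(N)c(C(=O)NCc1ccc(F)cc1F)c(=O)n2O` has not yet been measured. Relative to compound 2, it carries 2-(isopropylcarbamoyl)ethenyl in place of 4-phenylbutyl on an aromatic carbon, two atoms from the ring nitrogen: 2-(isopropylcarbamoyl)ethenyl in place of 4-phenylbutyl on an aromatic carbon. Going by the values given here, no measured pair shows what this exchange does, so the expectation starts from compound 2 at 13000 nM, and no step beyond the scatter is expected in either direction. The estimated change, a 1.2-fold higher number from compound 2 to compound 3 (0.06 log units; within the scatter), is therefore small, though the uncertainty is wide. For compound 3 the expected value is 15000 nM, with an estimated range of 3500 nM to 60000 nM.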

Compound 3, half-maximal cytotoxic concentration: > 250000 nM
Compound 3 ended at the assay's limit; the forecaster's own chance of this, stated with the estimate: 15%; at least 16-fold (1.22 log units) between middle value and limit.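

On an aromatic carbon two atoms from the ring nitrogen, replacing 4-phenylbutyl with 2-(isopropylcarbamoyl)ethenyl gives an at least 19-fold higher number from compound 2 to compound 3 (1.28 log units; beyond the scatter) in this assay, so what this position carries can shift the tolerated concentration by far more than the scatter. Going by these compounds alone, compound 1 and compound 2 differ in more than one place, so they could not isolate any single change; this pair is the first to tie a step to this position. Compound 3 sits at a limit of the assay and has no exact number, so the step gives only a minimum: the limit of > 250000 nM in this assay, at which 1 of the 3 values shown sits.

The compounds shown leave open whether the step follows from losing the six-membered aromatic ring or from gaining the double bonds and the amide. They also leave open how a simple amine or a carboxylic acid at this position would read in this assay.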